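The source may hold more compounds than are shown below. What is called first, only, known or untested is meant among the compounds shown, and "the series" means these compounds.

Compound 3 `CCC/N=C1\S/C(=C\c2ccc(O)c(C(C)C)c2)C(=O)N1c1ccccc1C` stands at 79000 nM in a physicochemical assay for solubility, measured as kinetic solubility (a higher number here means a more soluble compound, a lower number a less soluble compound), and lies within the scatter of compound 1 `CCC/N=C1\S/C(=C\c2ccc(O)cn2)C(=O)N1c1ccccc1C` at 110000 nM while compound 2 `CCC/N=C1\S/C(=C\c2ccc(O)c(C#N)c2)C(=O)N1c1ccccc1C` reads 220000 nM on the same core. Compound 4 `CCC/N=C1\S/C(=C\c2ccc(O)c(Br)c2)C(=O)N1c1ccccc1C` has not yet been measured. It carries bromo in place of isopropyl on an aromatic carbon ortho to a hydroxy group (bromo in place of isopropyl on an aromatic carbon). Among the measured compounds shown here, two measured steps bear on this change. The closer one exchanges cyano for isopropyl on that same aromatic carbon (a 2.8-fold lower number from compound 2 to compound 3 (0.44 log units; beyond the scatter)) and is modest. The other replaces the whole aromatic group (a 2.0-fold higher number from compound 1 to compound 2 (0.30 log units; within the scatter)) and does not leave the scatter. For the measured compounds named here, no compound with bromo has been measured, so the direction rests on little. With the modest size of the step to compound 3 (a 2.8-fold lower number from compound 2 to compound 3 (0.44 log units; beyond the scatter)) as the largest seen, only a small change is expected, and a slight rise at most. The expected step is a 1.3-fold higher number from compound 3 to compound 4 (0.10 log units; within the scatter) in this assay on this reading. For compound 4 the expected value is 100000 nM with 50000 nM to 200000 nM as its estimated range.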

Compound 4, solubility: 79000 nM
Estimate against measurement, compound 4: 1.3-fold (0.10 log units) above; the range from low to high includes it.
By their numbers in this assay, from the lowest: compounds 3, 4, 1 and 2 (each within the scatter of the next, the first and the last beyond it).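

In this assay bromo and isopropyl, on an aromatic carbon ortho to a hydroxy group, cannot be told apart (no change at the digits printed from compound 3 to compound 4 (within the scatter)), although three carbons leave and one bromine enters. At this position, the step from cyano to bromo (a 2.8-fold lower number from compound 2 to compound 4 (0.44 log units; beyond the scatter)) is the same size as the one from cyano to isopropyl, so compound 2 alone stands apart from both, while the exchange of the whole aromatic group for the bromo-bearing one stays small (a 1.4-fold lower number from compound 1 to compound 4 (0.14 log units; within the scatter)). No measurement shown here offers an explanation for these results.

The compounds shown leave open whether an amine, a carboxylic acid or a longer chain on this aromatic carbon would read with bromo and isopropyl or with cyano. They also leave open whether the match between bromo and isopropyl holds with a methoxy group in place of the hydroxy group.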